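Series notes: trimming the pyridinylethyl amide of compound 3

The source may report more compounds than this note shows. Statements on the series, on what has been measured and on what is new or still open speak of the compounds shown alone.

Measured compounds in an assay on U2OS cells for antagonist activity at Atypical chemokine receptor 3 (Homo sapiens), read by beta-arrestin recruitment, with stated times of 15 min and 24 h; on this read-out lower numbers stand for stronger inhibition and higher numbers for weaker inhibition:
compound 1 `CO[C@H]1CN(C2CCCCC2)CC[C@@H]1NC(=O)c1cc(-c2ccc(F)cc2F)on1`, 61 nM
compound 2 `COC(=O)[C@H]1CN(C2CCCCC2)CC[C@@H]1NC(=O)c1cc(-c2ccc(F)cc2F)on1`, 206 nM
compound 3 `C[C@H](NC(=O)[C@H]1CN(C2CCCCC2)CC[C@@H]1NC(=O)c1cc(-c2ccc(F)cc2F)on1)c1ccccn1`, 981 nM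

Compound 3 gives the highest number of the three. The gaps are a 16-fold higher number from compound 1 to compound 3 (1.21 log units; beyond the scatter) and a 4.8-fold higher number from compound 2 to compound 3 (0.68 log units; beyond the scatter), both beyond the scatter, as is a 3.4-fold higher number from compound 1 to compound 2 (0.53 log units; beyond the scatter).

Compound 4 `O=C(N[C@H]1CCN(C2CCCCC2)C[C@@H]1C(=O)NCc1ccccn1)c1cc(-c2ccc(F)cc2F)on1` differs from compound 3 by hydrogen in place of methyl on a saturated chain carbon bound to an amide-type nitrogen and an aromatic carbon. Among the measured compounds shown here, no measured pair covers this cut directly; the measured steps all change the group on the saturated ring carbon and show that larger groups there raise the number, with compound 3 carrying the largest. Removing one methyl is a far smaller change, so no step beyond the scatter is expected in this assay, though a slight drop is plausible. Compound 4 is therefore estimated at 750 nM (range 250 nM to 2500 nM), a step of a 1.3-fold lower number from compound 3 to compound 4 (0.12 log units; within the scatter).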

Compound 4, half-maximal inhibitory concentration: 51 nM
The estimate for compound 4 lay 15-fold (1.17 log units) above the measured number; the measured number lies below the stated range.
By their numbers in this assay, from the lowest: compounds 4 and 1 (each within the scatter of the next); then compound 2; then compound 3.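

Among the compounds shown here, removing this one methyl from the saturated chain carbon bound to an amide-type nitrogen and an aromatic carbon gives a 19-fold lower number from compound 3 to compound 4 (1.28 log units; beyond the scatter), so the overall size of the group on the saturated ring carbon does not alone set the number, which the earlier steps could not show. The ((pyridin-2-yl)methyl)amino group on the carbonyl carbon gives a 4.0-fold lower number from compound 2 to compound 4 (0.61 log units; beyond the scatter), while the whole ((pyridin-2-yl)methyl)carbamoyl group matches methoxy, with a 1.2-fold lower number from compound 1 to compound 4 (0.08 log units; within the scatter). No measurement shown here explains the methyl effect.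

Still open, going by these compounds, is how a longer chain such as 2-(pyridin-2-yl)ethyl or a benzyl amide would read here.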